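The source may report more compounds than this note shows. Statements on the series, on what has been measured and on what is new or still open speak of the compounds shown alone.

Of the compounds shown here, three built on a shared core have been tested in an ADME assay on PC-3 cells (Homo sapiens) for cytotoxicity, read by WST assay, tested at 100 uM; on this read-out lower numbers stand for less inhibition and higher numbers for more inhibition at the one concentration tested (going by the name of the read-out). Compound 1 `O=C(Nc1cccc(Oc2ccccn2)c1)C1CCCN(C(=O)c2cc(C(F)(F)F)cc(C(F)(F)F)c2)C1` gives 0% in this assay. Compound 3 `COC(=O)c1cc(-c2cccc(NC(=O)C3CCCN(C(=O)c4cc(C(F)(F)F)cc(C(F)(F)F)c4)C3)c2)co1` gives 0% in this assay, and the step of no change at the digits printed from compound 1 to compound 3 (within the scatter) shows that exchanging one ring group for another on this core left the read-out where it was. Among the compounds with values here, compound 2 `O=C(Nc1ccc(Cl)cc1)C1CCCN(C(=O)c2cccc(-c3ccco3)c2)C1` gives 0% in this assay, level with compound 1 and compound 3; on the numbers so far, none of the three compounds inhibits these cells at the one concentration tested.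

Compound 4 `O=C(Nc1ccc(Cl)cc1)C1CCCN(C(=O)c2cccc(-c3cnco3)c2)C1` differs from compound 2 by 1,3-oxazol-5-yl in place of furan-2-yl on an aromatic carbon. Within the data shown here, the only step measured on this core, from compound 1 to compound 3, also exchanged one ring group for another and brought no change, so nothing in the data argues for a shift in this assay when one five-membered aromatic ring takes the place of another. The step of no change at the digits printed from compound 2 to compound 4 (within the scatter) is therefore expected to stay within the scatter. For compound 4 the estimate in this assay is 0%, with a likely range from -5% to 12%.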

Compound 4, a percentage reported as inhibition, at one concentration (the size of the read-out at that concentration, not a potency): 0%
Beside the measured number, compound 4's estimate shows no gap at the digits printed, and the stated range covers the measured number.
By their numbers in this assay, from the lowest: compounds 1, 2, 3 and 4 (each within the scatter of the next).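

In this assay, the step at this position, on an aromatic carbon meta to a large group, is no change at the digits printed from compound 2 to compound 4 (within the scatter). This extends the earlier picture to a second place on the molecule: the ring exchanged here keeps its five heavy atoms but gains a second hetero atom and a second hydrogen-bond acceptor, and the read-out does not respond. No measurement here offers an explanation for this result.

Within the data shown here, since the read-out of compound 2 and compound 4 stands at zero, the step shows only that neither ring brings measurable inhibition at the one concentration tested, not how the two rings would compare in any other setting. From the compounds shown here alone, whether an amine or a carboxylic acid on this same aromatic carbon would also leave the read-out at the level of compound 4 remains open.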